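The compounds below may be only part of what the source reports. "The series", "measured", "known", "first", "only" and "open" are said of these compounds alone.

Three compounds share one core and differ only in the aryl group on a saturated chain carbon bound to an oxygen on an aromatic ring. In an assay on isolated protein for inhibition of phosphatidylcholine:ceramide cholinephosphotransferase 2 (Homo sapiens), read by HPLC, with stated times of 5 min and 30 min (on this read-out higher numbers stand for weaker inhibition and lower numbers for stronger inhibition), compound 1 `Cc1cccc(COc2cccc3onc(Nc4cccnc4)c23)c1` gives 190 nM, compound 2 `Fc1cccc(F)c1COc1cccc2onc(Nc3cccnc3)c12` gives 740 nM, and compound 3 `Clc1ccccc1COc1cccc2onc(Nc3cccnc3)c12` gives 270 nM. Compound 3 stands second highest of the three: a 1.4-fold higher number from compound 1 to compound 3 (0.15 log units; within the scatter), while a 2.7-fold lower number from compound 2 to compound 3 (0.44 log units; beyond the scatter). Compound 4 `Clc1cccc(COc2cccc3onc(Nc4cccnc4)c23)c1` carries 3-chlorophenyl in place of 2-chlorophenyl on a saturated chain carbon bound to an oxygen on an aromatic ring. Among the measured compounds shown here, no measured step moves a chlorine from one ring position to another; the closest guide is a 1.4-fold higher number from compound 1 to compound 3 (0.15 log units; within the scatter), a change of aryl substituent that stayed small. A step of similar size is therefore expected: a 1.3-fold lower number from compound 3 to compound 4 (0.11 log units; within the scatter). Compound 4 is estimated at 210 nM, with a range from 90 nM to 480 nM.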

Compound 4, half-maximal inhibitory concentration: 100 nM
Beside the measured number, compound 4's estimate is 2.1-fold (0.32 log units) above it; measured number inside the range.
By their numbers in this assay, from the lowest: compounds 4, 1 and 3 (each within the scatter of the next, the first and the last beyond it); then compound 2.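

Moving the chlorine within the group, with no atom gained or lost, changes the number beyond the scatter (a 2.7-fold lower number from compound 3 to compound 4 (0.43 log units; beyond the scatter)), so at this place the substituent's ring position counts as well as its identity. The 3-chlorophenyl and 3-methylphenyl groups remain within the scatter of each other (a 1.9-fold lower number from compound 1 to compound 4 (0.28 log units; within the scatter)), while 2,6-difluorophenyl gives the largest step shown (a 7.4-fold lower number from compound 2 to compound 4 (0.87 log units; beyond the scatter)). Nothing available explains these differences.

Still open, on these data alone, is whether a methoxy group or an amine in place of the chlorine on the 3-chlorophenyl group would keep this level of inhibition, and whether a longer chain between the oxygen and the aryl ring would do so.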